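Replacing the benzyl group of compound 3 with cyclohexylmethyl

A few compounds are considered here, and "the series" means these few. Any claim that something is new, unique, unknown or untested is made for them only; others in the source may bear on it.

Measured so far in a functional assay on CHO cells for antagonist activity at prostaglandin E2 receptor EP4 subtype (Homo sapiens), read by calcium flux, with a stated time of 15 min; a lower number here means a stronger inhibitor, a higher number a weaker inhibitor:
compound 1, `Cc1c(C(=O)N[C@@H](C)c2ccc(C(=O)O)cc2)nnn1Cc1ccc(C(F)(F)F)cc1`, gives > 10000 nM;
compound 2, `C[C@H](NC(=O)c1c(C(F)(F)F)nnn1Cc1cccc(C(F)(F)F)c1)c1ccc(C(=O)O)cc1`, gives 1970 nM;
compound 3, `C[C@H](NC(=O)c1c(-c2ccccc2)nnn1Cc1cccc(C(F)(F)F)c1)c1ccc(C(=O)O)cc1`, gives 23 nM.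

The value of compound 1 is a limit of this assay, not a number (the limit of > 10000 nM in this assay, at which 1 of the 3 values shown sits). Among the two numbers, compound 3 has the lowest; its nearest neighbour is compound 2, and the step between them is an 86-fold lower number from compound 2 to compound 3 (1.93 log units; beyond the scatter), brought about by phenyl in place of trifluoromethyl on an aromatic carbon of the shared core.

Compound 4, `C[C@H](NC(=O)c1c(-c2ccccc2)nnn1CC1CCCCC1)c1ccc(C(=O)O)cc1`, differs from compound 3 in one place: cyclohexyl in place of 3-(trifluoromethyl)phenyl on a saturated chain carbon bound to an aromatic nitrogen. None of the measured steps touches this part of the molecule; the one step shown concerns the aromatic carbon of the core, not the saturated chain carbon bound to the aromatic nitrogen, so it gives no direct guide. Compounds 1 and 2 differ from each other in two places and their values show only that one is a limit and the other a number. Within the data shown here, with no measured precedent, a modest loss of potency is expected for compound 4, the step being estimated as a 6.5-fold higher number from compound 3 to compound 4 (0.81 log units; beyond the scatter). Compound 4 is therefore expected to give about 150 nM in this assay, within a range of 30 nM to 800 nM.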

Compound 4, half-maximal inhibitory concentration: > 10000 nM
Compound 4 gave a limit, no number; the forecaster's own chance of this, stated with the estimate: 10%; at least 66-fold (1.82 log units) between middle value and limit.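

Among these compounds, this is the first measured change at the saturated chain carbon bound to an aromatic nitrogen; the earlier step concerned only the aromatic carbon of the shared core. In this assay compound 4 gives > 10000 nM, which is a limit and not a number. Cyclohexyl in place of 3-(trifluoromethyl)phenyl gives an at least 430-fold higher number from compound 3 to compound 4 (2.63 log units; beyond the scatter), so at this position activity in compound 3 does not survive this exchange of the aromatic ring and its trifluoromethyl group for a non-aromatic ring of carbon only.

The change removes the aromatic ring and the trifluoromethyl group together, so a plain phenyl or a pyridyl ring at this place would be needed to separate the two. How far compound 4 lies beyond the measurable range also stays open: the limit of > 10000 nM in this assay, at which 2 of the 4 values shown sit.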